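The compounds below may be only part of what the source reports. "The series", "measured", "known", "first", "only" and "open" are said of these compounds alone.

Compounds measured so far:
Compound 1, `COc1ccc(/C=C/C(=O)c2sc(Nc3ccc(Cl)c(Cl)c3)nc2C)cc1`: > 25000 nM
Compound 2, `Cc1ccccc1Nc1nc(C)c(C(=O)/C=C/c2ccc(Cl)cc2)s1`: > 25000 nM

In a functional assay on BGC-823 cells (Homo sapiens) for cytotoxicity, read by MTT assay (on this read-out lower numbers stand for stronger inhibition and higher numbers for weaker inhibition), compound 1 gives only a limit of the assay, > 25000 nM, and not a number. In this assay compound 2 likewise gives only a limit, > 25000 nM, so where compound 2 stands on the numbers shown is known only as a limit. Among the measured compounds shown here, the one further value shown is a limit as well: the limit of > 25000 nM in this assay, at which 2 of the 2 values shown sit. Nothing measured here therefore separates the two compounds from each other.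

Compound 3, `Cc1nc(Nc2ccc(Cl)c(Cl)c2)sc1C(=O)/C=C/c1ccc(Cl)cc1`, has not yet been measured. It differs from compound 2 in one place: 3,4-dichlorophenyl in place of 2-methylphenyl on a nitrogen on an aromatic ring. The 3,4-dichlorophenyl that enters is the same group that compound 1 carries on a nitrogen on an aromatic ring, and compound 1 sits at the limit > 25000 nM. For the measured compounds named here, no step between measured compounds is available to draw on, so the step from compound 2 to compound 3 is expected to be none beyond the scatter, a step that the limit leaves unreadable from compound 2 to compound 3, most likely ending again at a limit of the assay. Compound 3 is accordingly estimated at 30000 nM, within a range from 8000 nM to 100000 nM.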

Compound 3, half-maximal inhibitory concentration: 22700 nM
Compound 3: the middle estimate sits 1.3-fold (0.12 log units) above what was measured; the range from low to high includes it.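

In this assay, compound 3 gives 22700 nM, the first actual number among the compounds shown, so a change at this position can now be tied to a measured value. Setting 3,4-dichlorophenyl in place of 2-methylphenyl on a nitrogen on an aromatic ring gives an at least 1.1-fold lower number from compound 2 to compound 3 (0.04 log units; that floor lies within the scatter), and setting chloro in place of methoxy on an aromatic carbon gives an at least 1.1-fold lower number from compound 1 to compound 3 (0.04 log units; that floor lies within the scatter), so neither change is shown to have a real effect. The true size of both steps stays unknown because the two compounds they start from give only a limit: the limit of > 25000 nM in this assay, at which 2 of the 3 values shown sit.

Going by these compounds, it remains open how far the values of compound 1 and compound 2 really lie from that of compound 3, and so whether either change matters at all. On these data alone, it is also open whether a group carrying an amine or a carboxylic acid, in place of 3,4-dichlorophenyl on that nitrogen, would bring the number down by more than the usual scatter.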